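This account rests on a few compounds, and the source may have more. Where it says the series, first, only, none or still open, it means among the compounds named here.

Three compounds share the same core and differ only in the group attached to the amide carbonyl. Compound 1 `CC1=C(C(C)C(=O)N(C)CCN(C)C)c2cc(F)ccc2/C1=C\c1ccc([S+](C)[O-])cc1` carries a (2-(dimethylamino)ethyl)(methyl)amino group there and in a functional assay on HT-29 cells (Homo sapiens) for inhibition, read by CellTiter-Glo, with a stated time of 72 h (on this read-out lower numbers stand for higher toxicity in this test and higher numbers for lower toxicity in this test), compound 1 gives 11900 nM. Compound 2 `CC1=C(C(C)C(=O)NCCN2CCCCC2)c2cc(F)ccc2/C1=C\c1ccc([S+](C)[O-])cc1` gives 9670 nM in this assay, and the step of a 1.2-fold lower number from compound 1 to compound 2 (0.09 log units; within the scatter) is small. Compound 3 `CC1=C(C(C)C(=O)N2CCN(CCN(C)C)CC2)c2cc(F)ccc2/C1=C\c1ccc([S+](C)[O-])cc1` gives 38400 nM in this assay, the highest of the three numbers: the steps of a 3.2-fold higher number from compound 1 to compound 3 (0.51 log units; beyond the scatter) and a 4.0-fold higher number from compound 2 to compound 3 (0.60 log units; beyond the scatter) both point to a higher number once the amide nitrogen sits inside a piperazine ring.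

Compound 4 `CC1=C(C(C)C(=O)N2CCN(c3ccncc3)CC2)c2cc(F)ccc2/C1=C\c1ccc([S+](C)[O-])cc1` keeps that piperazine ring and changes only what hangs from its far nitrogen: pyridin-4-yl in place of 2-(dimethylamino)ethyl on an amine nitrogen in a ring. None of the three measured steps touches this position; each swaps the whole amide substituent rather than the group on the ring nitrogen, so they bear on the step only indirectly, showing that the piperazine-bearing compound 3 sits at the high end. Within the data shown here, with no measured step on this spot, the estimated step of a 1.3-fold lower number from compound 3 to compound 4 (0.11 log units; within the scatter) in this assay is expected to stay close to the scatter, in either direction. Compound 4 is therefore estimated at 30000 nM in this assay, within a range from 9000 nM to 90000 nM.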

Compound 4, half-maximal cytotoxic concentration: 4990 nM
Compound 4: the middle estimate sits 6.0-fold (0.78 log units) above what was measured; measured number below the stated range.
By their numbers in this assay, from the lowest: compounds 4, 2 and 1 (each within the scatter of the next, the first and the last beyond it); then compound 3.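

The earlier compounds shown here changed the whole amide substituent, whereas this pair shows that the far nitrogen of the piperazine ring is a sensitive position in its own right: pyridin-4-yl in place of 2-(dimethylamino)ethyl gives a 7.7-fold lower number from compound 3 to compound 4 (0.89 log units; beyond the scatter) in this assay. A piperazine ring on the carbonyl carbon therefore does not by itself give a high number, since the same comparison with the open-chain amides reads a 2.4-fold lower number from compound 1 to compound 4 (0.38 log units; beyond the scatter) and a 1.9-fold lower number from compound 2 to compound 4 (0.29 log units; within the scatter), so the higher number seen earlier holds for compound 3 while compound 4 goes against it. Nothing measured alongside these compounds explains why this swap moves the number.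

A single swap at this position cannot separate the gain of the aromatic ring from the loss of the 2-(dimethylamino)ethyl chain, and a plain phenyl ring or a small methyl group on the same nitrogen would help to tell these apart. From the compounds shown here alone, it also stays open whether the position of the ring nitrogen counts, which pyridin-2-yl or pyridin-3-yl in place of pyridin-4-yl would test.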